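The source may report more compounds than this note shows. Statements on the series, on what has been measured and on what is new or still open speak of the compounds shown alone.

Of the compounds shown here, two built on the same core have been measured in a functional assay (trachea) for antagonist activity, with Cavia porcellus as the target; a lower number here means a less potent compound, a higher number a more potent compound, by a factor of ten per unit of this negative logarithm. Compound 1 `COC(=O)C(C(=O)c1ccc(Cn2ccc3ccc(NC(=O)CC4CCCC4)cc32)c(OC)c1)S(=O)(=O)c1ccccc1` gives 10.1, the higher of the two numbers. Compound 2 `COc1cc(C(=O)NS(=O)(=O)c2cc(C)ccc2C)ccc1Cn1ccc2ccc(NC(=O)CC3CCCC3)cc21` gives 8.4, a gap below compound 1 that lies beyond the usual scatter. Since these two compounds differ in more than one place, the gap cannot be tied to any single change.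

Compound 3 `CCCCC(CC)C(=O)Nc1ccc2ccn(Cc3ccc(C(=O)C(C(=O)OC)S(=O)(=O)c4ccccc4)cc3OC)c2c1` has not yet been measured. It arises from compound 1 by 1-ethylpentyl in place of cyclopentylmethyl on a carbonyl carbon. Within the data shown here, no measured pair shows this change on its own, so there is no step from which to read its size directly. The group that leaves and the group that enters are both made of carbon only and sit on the same carbonyl carbon, so a modest shift seems more likely than a large one. Compound 3 is therefore expected to give about 9.9, in a range from 9.2 to 10.5. This amounts to an expected step of a number 0.20 log units lower from compound 1 to compound 3 (within the scatter), small enough to fall within the scatter, with no clear direction.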

Compound 3, negative logarithm of the antagonist equilibrium constant: 8.5
Compound 3: middle estimate off by 1.40 log units, on the high side, and the stated range ends above it.
By their numbers in this assay, from the lowest: compounds 2 and 3 (each within the scatter of the next); then compound 1.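

Exchanging cyclopentylmethyl for 1-ethylpentyl on the carbonyl carbon is the only difference between these two compounds, and in this assay it gives a number 1.60 log units lower from compound 1 to compound 3 (beyond the scatter) in a single step. The earlier pair differed in more than one place and could tie its gap to no single change, whereas this pair shows that the group at this position matters, even when both groups are made of carbon only and neither carries a hydrogen-bond donor or acceptor. Nothing measured here accounts for the drop, so it cannot be said whether the loss of the ring, the added carbon or the different shape of the chain is what counts.

On these data alone, what remains open is which of these differences carries the step: a cyclohexylmethyl group and a straight pentyl chain on the same carbonyl carbon would be two ways of pulling ring and chain apart. Also open, as far as these compounds go, is whether a group that is not carbon only, such as an amine or an ether chain, would be tolerated at this position.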